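The source may report more compounds than this note shows. Statements on the series, on what has been measured and on what is new or still open speak of the compounds shown alone.

Compound 3 `CO[C@@H]1O[C@H](COc2ccccc2)[C@@H](O)[C@H](O)[C@H]1Oc1ccc(OC2CCCCC2)cc1` gives 14% in a functional assay on MDA-MB-435 cells (Homo sapiens) for cytotoxicity, read by MTT assay, with a stated time of 48 h, tested at 20 uM; on this read-out lower numbers stand for less inhibition and higher numbers for more inhibition at the one concentration tested (going by the name of the read-out). On the numbers shown, compound 3 stands second highest of the three: compound 2 `CO[C@H]1O[C@H](COc2ccc3c(c2)CCCC3)[C@@H](O)[C@H](O)[C@H]1Oc1ccc(OC2CCCCC2)cc1` gives 16%, which lies within the scatter of compound 3, while compound 1 `CO[C@H]1O[C@H](COc2cccc3c2CCCC3)[C@@H](O)[C@H](O)[C@H]1Oc1ccc(OC2CCCCC2)cc1` gives -1%, and the gap from compound 1 up to compound 3 is beyond the scatter. Among the measured compounds shown here, the only measured step, a number 17 percentage points higher from compound 1 to compound 2 (beyond the scatter), concerns a change of the tetrahydronaphthalenyl group and is modest. Compound 4 `CO[C@H]1O[C@H](COc2ccccc2)[C@@H](O)[C@H](O)[C@H]1Oc1ccc(OC2CCCCC2)cc1` differs from compound 3 in this way: the two compounds have the same atoms and bonds and differ only in configuration as drawn: 1 of 5 stereo elements differ; a stereocentre at a saturated ring carbon is drawn R in compound 3 and S in compound 4. For the measured compounds named here, no measured step bears on a change of configuration alone, so no step beyond the scatter is expected in this assay. The step of no change at the digits printed from compound 3 to compound 4 (within the scatter) is expected to stay within the scatter. Compound 4 is therefore estimated at 14%, in the range 0% to 30%.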

Compound 4, a percentage reported as inhibition, at one concentration (the size of the read-out at that concentration, not a potency): -8%
Estimate against measurement, compound 4: 22 percentage points above; the measured number lies below the stated range.
By their numbers in this assay, from the lowest: compounds 4 and 1 (each within the scatter of the next); then compounds 3 and 2 (each within the scatter of the next).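

The configuration at this saturated ring carbon counts in this assay, with a number 22 percentage points lower from compound 3 to compound 4 (beyond the scatter), and that step belongs to this one stereocentre because of a single fact: the fact that compounds 3 and 4 differ only in the configuration as drawn. Among compounds drawn with the same configuration there, phenyl in place of 1,2,3,4-tetrahydronaphthalen-6-yl gives a number 24 percentage points lower from compound 2 to compound 4 (beyond the scatter), whereas phenyl in place of 1,2,3,4-tetrahydronaphthalen-5-yl gives a number 7 percentage points lower from compound 1 to compound 4 (within the scatter). On these data alone, whether the configuration step would recur with either tetrahydronaphthalenyl group remains open. So does how an amine or a carboxylic acid in place of the cyclohexyl group would read in this assay.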